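Aryl hydrazone variation on a shared core

The compounds below may be only part of what the source reports. "The series", "measured", "known", "first", "only" and "open" are said of these compounds alone.

Measured compounds:
compound 1 `COc1ccc(/C=N/Nc2nc3ccccc3nc2Cc2ccccc2)cc1OC`: 56 nM
compound 2 `COc1ccc(/C(C)=N/Nc2nc3ccccc3nc2Cc2ccccc2)cc1`: 89 nM
compound 3 `C/C(=N\Nc1nc2ccccc2nc1Cc1ccccc1)c1ccc(O)cc1`: 2.8 nM

In an assay on isolated protein for inhibition of Amine oxidase [flavin-containing] A (Homo sapiens), read by spectrophotometry (a lower number here means a stronger inhibitor, a higher number a weaker inhibitor), compound 1 gives 56 nM, the second highest of the three numbers. Its nearest neighbour is compound 2, whose value of 89 nM lies within the usual scatter of that of compound 1. For the measured compounds named here, compound 3, at 2.8 nM, stands far from both; the only single-point step among the measured compounds, a 32-fold lower number from compound 2 to compound 3 (1.50 log units; beyond the scatter), shows how strongly this assay responds to a change on the aryl ring of the hydrazone.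

Compound 4 `CN(C)c1ccc(/C=N/Nc2nc3ccccc3nc2Cc2ccccc2)cc1` differs from compound 1 by 4-(dimethylamino)phenyl in place of 3,4-dimethoxyphenyl on a carbon with a double bond to nitrogen. Going by the values given here, no measured step covers this exchange: the step from compound 2 to compound 3 concerns an oxygen substituent and does not bear directly on a dimethylamino for dimethoxy swap. The large size of that step only says that this part of the molecule can move the number a great deal in either direction. Among the compounds with values here, with no directly comparable precedent, compound 4 is expected to land near compound 1, with a wide range, giving an estimated step of a 1.2-fold lower number from compound 1 to compound 4 (0.09 log units; within the scatter). Compound 4 is thus estimated at 45 nM, between 8 nM and 250 nM.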

Compound 4, half-maximal inhibitory concentration: 83 nM
Estimate against measurement, compound 4: 1.8-fold (0.27 log units) below; the measured number falls inside the stated range.
By their numbers in this assay, from the lowest: compound 3; then compounds 1, 4 and 2 (each within the scatter of the next).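

In this assay, the exchange of 3,4-dimethoxyphenyl for 4-(dimethylamino)phenyl on a carbon with a double bond to nitrogen gives a 1.5-fold higher number from compound 1 to compound 4 (0.17 log units; within the scatter), so this change leaves the number where it was. The aromatic ring at this place therefore does not respond to every exchange: the much larger step a 32-fold lower number from compound 2 to compound 3 (1.50 log units; beyond the scatter) is not matched here, although a whole set of substituents changes. Nothing on hand explains why this exchange has so little effect on the number.

As far as these compounds go, it remains open whether the low number of compound 3 at 2.8 nM depends on the hydroxyl group alone or also on the methyl on the carbon with the double bond to nitrogen. Also open, from the compounds shown here alone, is how an amino group or a carboxylic acid would behave on this ring.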